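The source may report more compounds than this note shows. Statements on the series, on what has been measured and on what is new or still open speak of the compounds shown alone.

The account starts from three measured compounds. Compound 1, `CC(=O)NCCn1ccc2cccnc21`, gives 10000 nM in an assay (Ovis aries) for binding affinity to melatonin receptor type 1A (Homo sapiens); a higher number here means a weaker inhibitor, a lower number a stronger inhibitor. Compound 3, `CC(=O)NCCCOc1cccc2c1OCCO2`, gives 631 nM in this assay. Compound 2, `COc1ccc2cccc(C3CNC(=O)C3)c2c1`, gives 1580 nM in this assay, the second highest of the three numbers: compound 3 stands nearest, with a lower number beyond the scatter, and compound 1 stands furthest, with a higher number beyond the scatter.

Compound 4, `COc1ccc2cccc(CCCC(N)=O)c2c1`, has not yet been measured in this assay. It differs from compound 2 in one place: 3-carbamoylpropyl in place of 5-oxopyrrolidin-3-yl on an aromatic carbon. The ring in the group that leaves is opened, and the group that enters is a chain carrying a primary amide, placed on the same aromatic carbon, ortho to a fused ring and meta to a fused ring.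

Going by the values given here, no measured pair shows this particular change, so the expectation rests on compound 2 alone. Compound 4 is expected to give a lower number than compound 2, a step of a 4.0-fold lower number from compound 2 to compound 4 (0.60 log units; beyond the scatter), and its estimated value is 400 nM, in a range from 80 nM to 2500 nM.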

Compound 4, half-maximal inhibitory concentration: 20 nM
Compound 4: middle estimate off by 20-fold (1.30 log units), on the high side; the measured number lies below the stated range.
By their numbers in this assay, from the lowest: compound 4; then compound 3; then compound 2; then compound 1.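

Setting 3-carbamoylpropyl in place of 5-oxopyrrolidin-3-yl on this aromatic carbon gives a 79-fold lower number from compound 2 to compound 4 (1.90 log units; beyond the scatter) in this assay, the first step seen in this set, and a large one. The two groups have the same counts of heavy atoms, hydrogen-bond donors and acceptors, and they differ in that the ring is opened, yet this single change at this position moves the number far beyond the scatter. Nothing at hand accounts for the size of this step.

Only one open chain is shown, which leaves open whether the gain holds for a shorter or a longer chain on the same carbon. Also open, going by these compounds, is whether the primary amide is needed, something a methyl amide, an amine or a carboxylic acid in its place would test.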